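The source may hold more compounds than are shown below. What is called first, only, known or untested is meant among the compounds shown, and "the series" means these compounds.

The series shares one core, with a ring-bound amine nitrogen that carries either an aryl carbonyl or a sulfonyl cap. Compound 1 `COc1ccc(-c2cn3cc(C4=CCN(C(=O)c5ccc(Cl)cc5)CC4)ccc3n2)cc1OC` gives 12200 nM in a functional assay on HeLa cells (Homo sapiens) for antiproliferative activity, read by MTT assay, with a stated time of 48 h; on this read-out lower numbers stand for stronger inhibition and higher numbers for weaker inhibition. Compound 2 `COc1ccc(-c2cn3cc(C4=CCN(C(=O)c5cccc(C(F)(F)F)c5)CC4)ccc3n2)cc1OC` gives 4860 nM and compound 3 `COc1ccc(-c2cn3cc(C4=CCN(S(=O)(=O)c5ccccc5)CC4)ccc3n2)cc1OC` gives 12600 nM in this assay. Compound 3 thus carries the highest number of the three, although a 1.0-fold higher number from compound 1 to compound 3 (0.01 log units; within the scatter) and only a 2.6-fold higher number from compound 2 to compound 3 (0.41 log units; beyond the scatter) sets it apart from compound 2. Compound 4 `COc1ccc(-c2cn3cc(C4=CCN(S(=O)(=O)C5CCCCC5)CC4)ccc3n2)cc1OC` differs from compound 3 by cyclohexyl in place of phenyl on a sulfonyl sulfur in that the ring on the sulfonyl sulfur is saturated. Among the compounds with values here, no measured step exchanges one group on the sulfonyl sulfur for another; the steps that touch this end of the molecule, namely a 2.5-fold lower number from compound 1 to compound 2 (0.40 log units; beyond the scatter) together with the two changes of cap just given, were modest or within the scatter, so the cap has so far moved the number only a little. On that basis no step beyond the scatter is expected for compound 4 in either direction. The expected step is a 1.1-fold lower number from compound 3 to compound 4 (0.02 log units; within the scatter) in this assay. For compound 4 the estimated value in this assay is 12000 nM with a range from 5000 nM to 30000 nM around it.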

Compound 4, half-maximal inhibitory concentration: 9990 nM
Compound 4: the middle estimate sits 1.2-fold (0.08 log units) above what was measured, within the range that was stated.
By their numbers in this assay, from the lowest: compound 2; then compounds 4, 1 and 3 (each within the scatter of the next).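

Within this assay the sulfonyl sulfur now has its first direct exchange of one group for another, and a 1.3-fold lower number from compound 3 to compound 4 (0.10 log units; within the scatter) shows that cyclohexyl can replace phenyl at this position with no change beyond the scatter. Compound 2 still stands apart from the sulfonyl series with a 2.1-fold higher number from compound 2 to compound 4 (0.31 log units; beyond the scatter) and this step is modest, while a 1.2-fold lower number from compound 1 to compound 4 (0.09 log units; within the scatter) leaves the cyclohexylsulfonyl and (4-chlorophenyl)carbonyl caps level within the scatter. No supporting data bear on why the exchange on the sulfonyl sulfur moves the number so little.

Open, going by these compounds, is whether an amine, a carboxylic acid or a longer chain on the sulfonyl sulfur would move the number beyond the scatter. Also open, on these data alone, is whether a trifluoromethyl group on the phenylsulfonyl cap would bring a sulfonyl compound closer to compound 2.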